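Bromo to Fluoro: What to Expect for Compound 4

A few compounds are considered here, and "the series" means these few. Any claim that something is new, unique, unknown or untested is made for them only; others in the source may bear on it.

Compound 2 `O=C(/C=C/c1cccc(Br)c1)c1ccccc1O` gives 48.4% in a functional assay on HCT-116 cells (Homo sapiens) for cytotoxicity, read by MTT assay, with a stated time of 48 h, tested at 10 uM (on this read-out higher numbers stand for a weaker effect at the one concentration tested and lower numbers for a stronger effect), the lowest of the three numbers measured. Compound 1 `O=C(/C=C/c1ccc(Br)cc1)c1ccccc1O` gives 85.5% and compound 3 `O=C(/C=C/c1ccc(Cl)cc1)c1ccccc1O` gives 84.8%, both standing beyond the scatter above compound 2. Compound 4 `O=C(/C=C/c1cccc(F)c1)c1ccccc1O` differs from compound 2 by fluoro in place of bromo on an aromatic carbon. Among the compounds with values here, the only measured step of a related kind is a number 0.7 percentage points lower from compound 1 to compound 3 (within the scatter), a halogen exchange that left the number essentially where it was. That step swaps chloro for bromo rather than fluoro, so it bears only loosely on the present change. Compound 4 is therefore expected to show a modest step toward a weaker effect in this assay, namely a number 13.6 percentage points higher from compound 2 to compound 4 (beyond the scatter). Compound 4 is estimated at 62%, within 42% to 85%.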

Compound 4, a percentage reported as activity, at one concentration (the size of the read-out at that concentration, not a potency): 90.2%
Beside the measured number, compound 4's estimate is 28.2 percentage points below it; the whole stated range lies below it.
By their numbers in this assay, from the lowest: compound 2; then compounds 3, 1 and 4 (each within the scatter of the next).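

Changing the halogen at this place, on an aromatic carbon meta to a large group, is far from neutral in this assay: fluoro in place of bromo gives a number 41.8 percentage points higher from compound 2 to compound 4 (beyond the scatter), a large step. The earlier halogen exchange, a number 0.7 percentage points lower from compound 1 to compound 3 (within the scatter), gave no sign of such a shift. Here, the stronger effect of compound 2 is lost once bromo gives way to fluoro, and no measurement shown accounts for this.

Still open, as far as these compounds go, is where chloro at this place would fall between compound 2 and compound 4. Also open, from the compounds shown here alone, is how an amine or a methoxy group there would read.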